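The compounds below may be only part of what the source reports. "The series", "measured", "known", "first", "only" and "open" are said of these compounds alone.

Compound 1, `CC(C)c1n[nH]c2c(NCc3ccc(-c4ccccn4)cc3)nc(SCCNC(=N)N)nc12`, is one of three analogues sharing a common core and differing only in the group attached to the sulfur. In a functional assay on HT cells (Homo sapiens) for antiproliferative activity, read by fluorescence, with a stated time of 72 h (a higher number here means a weaker inhibitor of growth, a lower number a stronger inhibitor of growth), compound 1 gives 390 nM, the highest of the three numbers; compound 2, `CC(C)c1n[nH]c2c(NCc3ccc(-c4ccccn4)cc3)nc(SC(C)C(C)O)nc12`, gives 190 nM, and compound 3, `CC(C)c1n[nH]c2c(NCc3ccc(-c4ccccn4)cc3)nc(SC[C@H](O)CN)nc12`, gives 63 nM. Both neighbours therefore sit below compound 1, by a 2.1-fold lower number from compound 1 to compound 2 (0.31 log units; beyond the scatter) and by a 6.2-fold lower number from compound 1 to compound 3 (0.79 log units; beyond the scatter), while the gap between them is a 3.0-fold lower number from compound 2 to compound 3 (0.48 log units; beyond the scatter).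

Compound 4, `CC(C)c1n[nH]c2c(NCc3ccc(-c4ccccn4)cc3)nc(SCC(C)(C)O)nc12`, has not yet been measured. It departs from compound 1 in one place: a group of 4 heavy atoms (3 carbon, 1 oxygen; no ring) in place of a group of 5 heavy atoms (2 carbon, 3 nitrogen; no ring), on a saturated chain carbon bound to a sulfur. Going by the values given here, the change most comparable among the measured ones is the one leading to compound 2, where a hydroxyl-bearing alkyl group without nitrogen also replaced the nitrogen-rich group and brought a 2.1-fold lower number from compound 1 to compound 2 (0.31 log units; beyond the scatter). The larger drop to compound 3, a 6.2-fold lower number from compound 1 to compound 3 (0.79 log units; beyond the scatter), came with a group that kept an amine, which compound 4 does not. A modest step downward in this assay, beyond the scatter but closer to what compound 2 showed than to compound 3, is therefore expected: a 2.3-fold lower number from compound 1 to compound 4 (0.36 log units; beyond the scatter). Compound 4 is estimated at 170 nM, with a likely range from 70 nM to 400 nM.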

Compound 4, concentration for 50% growth inhibition: 507 nM
Compound 4: middle estimate off by 3.0-fold (0.47 log units), on the low side, outside the stated range (above it).
By their numbers in this assay, from the lowest: compound 3; then compound 2; then compounds 1 and 4 (each within the scatter of the next).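

Placing 1-hydroxy-1-methylethyl on the saturated chain carbon bound to a sulfur gives a 1.3-fold higher number from compound 1 to compound 4 (0.11 log units; within the scatter) and so leaves compound 4 level with compound 1 in this assay, even though this group has no nitrogen and the group it replaces is rich in it. Compounds 2 and 4 both carry a hydroxyl group and no nitrogen at this position, yet 2-hydroxy-2-methylpropyl in place of 2-hydroxy-1-methylpropyl on a sulfur gives a 2.7-fold higher number from compound 2 to compound 4 (0.43 log units; beyond the scatter) and shows that the hydroxyl group alone does not fix the number here. 1-Hydroxy-1-methylethyl in place of 2-amino-1-hydroxyethyl gives an 8.0-fold higher number from compound 3 to compound 4 (0.91 log units; beyond the scatter) and makes this the largest step among these compounds, which sets compound 3 apart, though nitrogen in the group does not by itself bring a low number, as compound 1 goes against that reading.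

Nothing shown here accounts for these steps. Still open, as far as these compounds go, is how a 2-aminoethyl group without a hydroxyl group, or a carboxylic acid on the same chain, would read in this assay and whether the amine of compound 3 needs its hydroxyl partner.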